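Swapping the aromatic ring substituent in a macrophage inhibition series

A few compounds are considered here, and "the series" means these few. Any claim that something is new, unique, unknown or untested is made for them only; others in the source may bear on it.

In a functional assay on BMDM cells (Mus musculus, strain C57BL/6) for inhibition, with a stated time of 2 days (on this read-out lower numbers stand for stronger inhibition and higher numbers for weaker inhibition), compound 1 `Nc1cccc(-c2cn(CC(=O)Nc3nccs3)nn2)c1` gives 1270 nM, the lowest number among the three compounds measured. Compound 2 `CCOC(=O)c1sc(NC(=O)Cn2cc(-c3ccc(OC)cc3)nn2)nc1C` gives 2330 nM, which lies within the usual scatter of that value, while compound 3 `Cc1cc(NC(=O)Cn2cc(-c3ccc(C#N)cc3)nn2)no1` gives 9320 nM, well beyond it. Compound 4 `O=C(Cn1cc(-c2ccccc2Cl)nn1)Nc1nccs1` has not been measured yet. It differs from compound 1 in one place: 2-chlorophenyl in place of 3-aminophenyl on an aromatic carbon. Among the compounds with values here, no single-change step between measured compounds is available to gauge this swap, and the measured compounds differ from each other in more than one place, so the expectation rests on the spread of the numbers seen. The step of a 2.0-fold higher number from compound 1 to compound 4 (0.29 log units; within the scatter) is expected to be a modest move toward a higher number, near the edge of the scatter. For compound 4 a value of about 2500 nM is estimated, with a plausible range from 800 nM to 8000 nM.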

Compound 4, half-maximal inhibitory concentration: 60 nM
Estimate against measurement, compound 4: 42-fold (1.62 log units) above; measured number below the stated range.
By their numbers in this assay, from the lowest: compound 4; then compounds 1 and 2 (each within the scatter of the next); then compound 3.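

In this assay, putting 2-chlorophenyl in place of 3-aminophenyl on an aromatic carbon gives a 21-fold lower number from compound 1 to compound 4 (1.33 log units; beyond the scatter), the first single-change step available here. This position is therefore sensitive to which aromatic group it carries, even though both groups have the same heavy-atom count. No measured evidence explains the drop.

This one swap removes the amino group, adds chlorine and changes the substituent's ring position, so the compounds shown cannot separate these changes. Unsubstituted phenyl, 3-chlorophenyl and 2-aminophenyl at this place remain open.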